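This account rests on a few compounds, and the source may have more. Where it says the series, first, only, none or still open, it means among the compounds named here.

Measured so far in a functional assay on KB cells (Homo sapiens) for antiproliferative activity, read by MTT assay, with a stated time of 48 h; on this read-out higher numbers stand for weaker inhibition and lower numbers for stronger inhibition:
compound 1 `Cn1cc(C2=C(c3nn(CCCN4CCCCC4)c4ncccc34)C(=O)N(c3ccccn3)C2=O)c2ccccc21` — > 100000 nM.
compound 2 `Cn1cc(C2=C(c3nn(CCCCn4ccnc4)c4ncccc34)C(=O)N(c3ccccc3)C2=O)c2ccccc21` — 47300 nM.

For compound 1 the result in this assay is a limit, > 100000 nM, and not a number. Going by the values given here, compound 2 is the only compound with an actual number in this assay, 47300 nM, so there is nothing measured to set it against. Among the compounds with values here, the one other value shown, that of compound 1, is a limit (the limit of > 100000 nM in this assay, at which 1 of the 2 values shown sits). Compound 3 `Cn1cc(C2=C(c3nn(CCCN4CCCCC4)c4ncccc34)C(=O)N(c3ccccc3)C2=O)c2ccccc21` has not been measured. It differs from compound 2 in one place: piperidin-1-yl in place of (1H-imidazol-1-yl)methyl on a saturated chain carbon, three bonds along the chain from an aromatic nitrogen. Within the data shown here, no measured pair differs in exactly this way, so the size of the step cannot be read from the data. Compound 1 carries the same piperidin-1-yl chain as compound 3 but a different group elsewhere on the shared core. That it returned only a limit says nothing more than that the series sits at the weak end of this assay. The step from compound 2 to compound 3 in this assay is expected to be small, a 1.4-fold higher number from compound 2 to compound 3 (0.14 log units; within the scatter), towards weaker inhibition if anything, and not clearly beyond the scatter. Compound 3 is estimated at 65000 nM, between 20000 nM and 200000 nM, with a real chance that only a limit is returned.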

Compound 3, half-maximal inhibitory concentration: 5600 nM
Beside the measured number, compound 3's estimate is 12-fold (1.06 log units) above it, and the stated range ends above it.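

In this assay, going by these compounds alone, the group at the end of the chain is not neutral: piperidin-1-yl in place of (1H-imidazol-1-yl)methyl on a saturated chain carbon, three bonds along the chain from an aromatic nitrogen, gives an 8.4-fold lower number from compound 2 to compound 3 (0.93 log units; beyond the scatter), the first readable step at this position. With the 3-(piperidin-1-yl)propyl chain held fixed, the shared core also responds at a second place, where phenyl in place of pyridin-2-yl on an amide-type nitrogen in a ring gives an at least 17-fold lower number from compound 1 to compound 3 (1.25 log units; beyond the scatter). The result for compound 1 is a limit and not a number, so this second step gives no exact size: the limit of > 100000 nM in this assay, at which 1 of the 3 values shown sits.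

The step at the chain reads the same when cut further out as 4-(1H-imidazol-1-yl)butyl to 3-(piperidin-1-yl)propyl, so the compounds shown do not separate the change of ring from the change of chain length; a shorter chain carrying 1H-imidazol-1-yl or a longer chain carrying piperidin-1-yl would be needed for that. Also open, going by these compounds, is whether the number of compound 3 depends on the piperidine ring itself or would hold with morpholin-4-yl or an open-chain amine such as dimethylamino on the same chain.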